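The source may report more compounds than this note shows. Statements on the series, on what has been measured and on what is new or still open speak of the compounds shown alone.

Measured compounds in an in vitro ADME assay on microsomes from liver (Homo sapiens) for metabolic stability; on this read-out lower numbers stand for slow clearance and higher numbers for fast clearance:

compound 1, `CNCc1ccccc1Oc1ccc(Cl)cc1F`: 22 mL.min-1.g-1
compound 2, `CNCc1cc(C#N)ccc1Oc1ccc(Cl)cc1OC`: "not determined" (no result reported)
compound 3, `CNCc1cc(C#N)ccc1Oc1ccc(Cl)cc1Cl`: "not determined" (no result reported)

Within the data shown here, compound 2 stands without a single number in this assay, and compound 3 is a further entry without a number, so the only figure is the one for compound 1. Among the measured compounds shown here, no step between measured compounds exists in this set, and nothing can be said of how the cyano group moves the read-out.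

Compound 4, `CNCc1ccccc1Oc1ccc(Cl)cc1OC`, is to be measured in this assay. It differs from compound 2 in one place: hydrogen in place of cyano on an aromatic carbon. The change removes the cyano group and leaves the rest of compound 2 untouched.

With compound 2 having no number, the size of the step cannot be read from the series. The expectation is a step of no fixed direction, and an outcome in this assay close to the one figure available, because compound 1 gives 22 mL.min-1.g-1 and shares the core and the (methylamino)methyl group with compound 4, differing only on the second ring.

For compound 4 the estimate in this assay is 25 mL.min-1.g-1, with an expected range from 10 mL.min-1.g-1 to 60 mL.min-1.g-1.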

Compound 4, intrinsic clearance in microsomes: 9 mL.min-1.g-1
The estimate for compound 4 lay 2.8-fold (0.44 log units) above the measured number, and the stated range ends above it.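

In this assay the series now holds its first readable step (a 2.4-fold lower number from compound 1 to compound 4 (0.39 log units; beyond the scatter)), for methoxy in place of fluoro on an aromatic carbon, and both compounds carry hydrogen at the place that holds cyano in compound 2. With hydrogen at that place, the change on the second ring alone therefore moves the read-out beyond the usual scatter, and compound 4 supplies the hydrogen side of the comparison with compound 2, but the steps involving compound 2 or compound 3 cannot be read without numbers for those compounds. No measured evidence bears on what lies behind the step from fluoro to methoxy.

The compounds shown leave open whether cyano, meta to a (methylamino)methyl group and para to a large group, raises or lowers the read-out relative to hydrogen, and whether its effect differs between the methoxy and chloro partners on the second ring. Also open, as far as these compounds go, is how a carboxylic acid or a primary amide at that place would compare with hydrogen, and whether ethoxy or a longer alkoxy chain would extend the step seen with methoxy.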